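Indanone series: amino in place of hydroxy

This account rests on a few compounds, and the source may have more. Where it says the series, first, only, none or still open, it means among the compounds named here.

Compound 1 `COc1cc(/C=C2\Cc3c(cc(OC)c(OC)c3OC)C2=O)cc(OC)c1OC` and compound 2 `COc1ccc(/C=C2\Cc3cc(OC)c(OC)c(OC)c3C2=O)cc1O` share the same core and differ in where the methoxy groups sit and in the hydroxy group carried by compound 2. In a functional assay on MDA-MB-231 cells (Homo sapiens) for antiproliferative activity, read by MTT assay, with a stated time of 48 h (a higher number here means a weaker inhibitor of growth, a lower number a stronger inhibitor of growth), compound 1 gives 5840 nM. For compound 2 the result in this assay is a limit of the assay, > 10000 nM, so compound 2 stands at the upper limit without a number of its own (the limit of > 10000 nM in this assay, at which 1 of the 2 values shown sits). Within the data shown here, no measured pair differs in one place, so no measured step is available here.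

Compound 3 `COc1ccc(/C=C2\Cc3cc(OC)c(OC)c(OC)c3C2=O)cc1N` is the next member and has not yet been measured in this assay. It differs from compound 2 by amino in place of hydroxy on an aromatic carbon; the change sits on an aromatic carbon of a six-membered aromatic ring of carbon only, ortho to a methoxy group and meta to a large group. With compound 2 known only as a limit, the step can be judged from that limit alone. Compound 3 is expected to stay near the weak end, with an expected step of a number no higher from compound 2 to compound 3 (the limit leaves the size open) of no clear direction beyond the scatter. The estimate for compound 3 in this assay is 10000 nM, within 4000 nM to 25000 nM.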

Compound 3, concentration for 50% growth inhibition: > 10000 nM
Compound 3: no number, only a limit; the forecaster's own chance of this, stated with the estimate: 50%; the middle value sits exactly at the limit.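

Compound 2 and compound 3 are both known in this assay only as limits of the assay, so no step between them can be read: the limit of > 10000 nM in this assay, at which 2 of the 3 values shown sit.

The compounds shown leave open whether amino in place of hydroxy on an aromatic carbon changes growth inhibition at all, with neither compound carrying a number of its own.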